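A Chloro Swap on the Lowest Number So Far

The source may hold more compounds than are shown below. What is called first, only, known or untested is meant among the compounds shown, and "the series" means these compounds.

Compound 1 `Cc1cc(Nc2cc(N3CCN(C)CC3)nc(Nc3ccc(S(N)(=O)=O)cc3)n2)n[nH]1` gives 100 nM
Compound 2 `Cc1cc(Nc2cc(N3CCN(C)CC3)nc(Nc3ccc([N+](=O)[O-])cc3)n2)n[nH]1` gives 43.3 nM
Compound 3 `Cc1cc(Nc2cc(N3CCN(C)CC3)nc(Nc3ccc(Cl)cc3)n2)n[nH]1` is not yet measured

Going by the values given here, in a functional assay on U-937 cells (Homo sapiens) for antiproliferative activity, read by CCK-8 assay, with a stated time of 72 h (on this read-out lower numbers stand for stronger inhibition and higher numbers for weaker inhibition), compound 2 stands lowest of the two numbers so far (43.3 nM), with compound 1 as its only neighbour. Moving to compound 3 puts chloro in place of nitro on an aromatic carbon, para to a large group (chloro in place of nitro on an aromatic carbon). Among the compounds with values here, one measured step bears on this, a modest one beyond the scatter that also replaced a group on that carbon (a 2.3-fold lower number from compound 1 to compound 2 (0.36 log units; beyond the scatter)). It swapped a different pair of groups, so it hints at size but not at direction. In this assay a similarly small change is therefore expected, leaning towards a higher number, as compound 2 already sits lowest (43.3 nM). The estimate amounts to an expected 1.5-fold higher number from compound 2 to compound 3 (0.18 log units; within the scatter) here. For compound 3 the estimated value is 65 nM (expected range 20 nM to 190 nM).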

Compound 3, half-maximal inhibitory concentration: 55.4 nM
For compound 3 the middle estimate is 1.2-fold (0.07 log units) above the measured one; low and high end bracket the measured number.
By their numbers in this assay, from the lowest: compounds 2, 3 and 1 (each within the scatter of the next, the first and the last beyond it).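

In this assay, the group on this aromatic carbon can change from nitro, with its three heavy atoms and two hydrogen-bond acceptors, to a single chlorine atom with no acceptors, and the step stays within the scatter (a 1.3-fold higher number from compound 2 to compound 3 (0.11 log units; within the scatter)). Chloro is not separated from sulfamoyl either (a 1.8-fold lower number from compound 1 to compound 3 (0.26 log units; within the scatter)), so compound 3 lies within the scatter of both compound 1 and compound 2, although those two lie beyond the scatter of each other. Nothing measured here explains these numbers.

From the compounds shown here alone, whether an amine, a carboxylic acid or a methoxy group on the same carbon would give a similar number remains open, as does whether bromo or fluoro would read like chloro. Also open, going by these compounds, is whether chloro in place of nitro gives an equally small step when another part of the core differs.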